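The source may hold more compounds than are shown below. What is called first, only, known or untested is meant among the compounds shown, and "the series" means these compounds.

In a physicochemical assay for lipophilicity (a higher number here means a more lipophilic compound, a lower number a more polar compound), compound 2 `O=S(=O)(Nc1nccs1)c1ccc2c(c1)OCC[C@H]2c1ccc(C(F)(F)F)cc1-n1ccnn1` gives 2.3, the lowest number of the three measured. Compound 3 `Cc1nc(-c2cc(C(F)(F)F)ccc2[C@H]2CCOc3cc(S(=O)(=O)Nc4ncc(F)cn4)ccc32)co1` gives 2.8, and compound 1 `Cc1nc(-c2cc(C(F)(F)F)ccc2[C@H]2CCOc3cc(S(=O)(=O)Nc4cccc(F)n4)ccc32)co1` gives 4. Compound 4 `O=S(=O)(Nc1nccs1)c1ccc2c(c1)OCC[C@H]2c1ccc(C(F)(F)F)cc1-c1ccc(F)cc1` departs from compound 2 in one place: 4-fluorophenyl in place of 1H-1,2,3-triazol-1-yl on an aromatic carbon. Going by the values given here, no measured step makes this exchange. The only one, a number 1.20 log units lower from compound 1 to compound 3 (beyond the scatter), sits on a sulfonamide nitrogen, so it bears only indirectly, showing that a single aromatic exchange in this set can move the number by a large amount. A large rise is therefore expected here, as a ring of carbon only replaces one with hetero atoms. The expected step is a number 1.40 log units higher from compound 2 to compound 4 (beyond the scatter). The estimate for compound 4 is 3.7, with an estimated range of 3.1 to 4.3.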

Compound 4, distribution coefficient: 4.5
Compound 4: the middle estimate sits 0.80 log units below what was measured, outside the stated range (above it).
By their numbers in this assay, from the lowest: compound 2; then compound 3; then compound 1; then compound 4.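

In this assay, going by these compounds alone, putting 4-fluorophenyl in place of 1H-1,2,3-triazol-1-yl gives a number 2.20 log units higher from compound 2 to compound 4 (beyond the scatter), the first measured exchange on this aromatic carbon, ortho to a large group and meta to a trifluoromethyl group. The number thus responds strongly at this position as well as on the sulfonamide nitrogen, though this rests on a single pair. No measurement given here accounts for the size of this step. The compounds shown leave open how much of the step belongs to the fluorine, and how an unsubstituted phenyl or an aliphatic amine would read at this carbon.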